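This account rests on a few compounds, and the source may have more. Where it says the series, first, only, none or still open, it means among the compounds named here.

Of the compounds shown here, three sharing one core have been measured so far, differing only in what sits on a sulfonamide nitrogen. Compound 1 `CC1(C)C=C(n2ccccc2=O)c2cc(S(N)(=O)=O)ccc2O1` carries a hydrogen there, and in a functional assay with Rattus norvegicus as the target (on this read-out higher numbers stand for an effect only at larger amounts of compound and lower numbers for an effect already at smaller amounts), compound 1 gives 69.2 nM. Compound 2 `CCNS(=O)(=O)c1ccc2c(c1)C(n1ccccc1=O)=CC(C)(C)O2` carries an ethyl, and in this assay compound 2 gives 56.2 nM. Compound 3 `CC1(C)C=C(n2ccccc2=O)c2cc(S(=O)(=O)NCCO)ccc2O1` carries a 2-hydroxyethyl, and in this assay compound 3 gives 110 nM. Compound 3 therefore has the highest of the three numbers, yet its distances to the other two are small: a 1.6-fold higher number from compound 1 to compound 3 (0.20 log units; within the scatter) and a 2.0-fold higher number from compound 2 to compound 3 (0.29 log units; within the scatter), both within the scatter, as is a 1.2-fold lower number from compound 1 to compound 2 (0.09 log units; within the scatter).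

The next compound, compound 4 `CC1(C)C=C(n2ccccc2=O)c2cc(S(=O)(=O)Nc3ccc([N+](=O)[O-])cc3)ccc2O1`, introduces a different kind of group at the same place: 4-nitrophenyl in place of 2-hydroxyethyl on a sulfonamide nitrogen. The three measured steps all concern small saturated groups or a hydroxy on such a chain, and all stayed within the scatter. None of them involves an aromatic ring at this position, so they give no direct guide to the size of the new step. Given that the measured variation at this nitrogen has so far been small, the expectation for compound 4 is a step of a 1.4-fold higher number from compound 3 to compound 4 (0.13 log units; within the scatter), with real uncertainty about the direction. The estimated value for compound 4 in this assay is 150 nM, expected to lie between 40 nM and 600 nM.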

Compound 4, half-maximal effective concentration: 2090 nM
For compound 4 the middle estimate is 14-fold (1.14 log units) below the measured one; measured number outside the range, above it.
By their numbers in this assay, from the lowest: compounds 2, 1 and 3 (each within the scatter of the next); then compound 4.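

At the sulfonamide nitrogen, hydrogen, ethyl and 2-hydroxyethyl gave numbers within the scatter of one another, which could have suggested that this position hardly matters, but 4-nitrophenyl shows otherwise. In this assay the change gives a 19-fold higher number from compound 3 to compound 4 (1.28 log units; beyond the scatter) and a 37-fold higher number from compound 2 to compound 4 (1.57 log units; beyond the scatter) as well as a 30-fold higher number from compound 1 to compound 4 (1.48 log units; beyond the scatter) in the comparison with the unsubstituted sulfonamide, so all three earlier compounds give large steps in the same direction, and much more compound is needed for the effect once this group is present. The tolerance seen so far therefore extends only to hydrogen and the two small chains, and it does not cover every group placed on this nitrogen, since the 4-nitrophenyl group brings in a six-membered aromatic ring and a nitro group in a single change.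

Nothing available here explains why the number rises so sharply. As far as these compounds go, whether the ring itself or the nitro group on it goes with the rise stays open, and a plain phenyl group, a 4-aminophenyl group or a longer chain such as hexyl on the same nitrogen would help to separate the two.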